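Two Diaryl Compounds and a Bromine Swap

This account rests on a few compounds, and the source may have more. Where it says the series, first, only, none or still open, it means among the compounds named here.

Compound 1 `COc1ccc(C2=C(c3ccc(SC)cc3)CC3CCCN3C2=O)cc1OC(=O)C1CCCN1C(=O)OC(C)(C)C`: 10000 nM
Compound 2 `COc1ccc(C2=C(c3ccc(SC)cc3)CC3CCCN3C2=O)cc1C`: 15000 nM

In a functional assay on SK-OV-3 cells (Homo sapiens) for cytotoxicity (a higher number here means a weaker inhibitor of growth, a lower number a stronger inhibitor of growth), compound 2 gives 15000 nM, which lies within the scatter of compound 1 at 10000 nM. Compound 3 `CSc1ccc(C2=C(c3ccc(Br)cc3)C(=O)N3CCCC3C2)cc1` has 4-bromophenyl in place of 4-methoxy-3-methylphenyl on a double-bonded ring carbon. Going by the values given here, no measured step shows the effect of such a swap, so no shift beyond the scatter is expected, and the estimated change is small: a 1.3-fold lower number from compound 2 to compound 3 (0.10 log units; within the scatter). For compound 3 the estimated value is 12000 nM, with an expected range of 4000 nM to 40000 nM.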

Compound 3, concentration for 50% growth inhibition: 9000 nM
For compound 3 the middle estimate is 1.3-fold (0.12 log units) above the measured one; measured number inside the range.
By their numbers in this assay, from the lowest: compounds 3, 1 and 2 (each within the scatter of the next).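

Within this assay the swap of 4-methoxy-3-methylphenyl for 4-bromophenyl on the double-bonded ring carbon gives a 1.7-fold lower number from compound 2 to compound 3 (0.22 log units; within the scatter) and so offers the first step read at this position: these two aryl groups are not told apart, although the entering one has bromine and no hydrogen-bond acceptor. No measurement at hand offers an explanation for this result. As far as these compounds go, whether an amine or a carboxylic acid on this ring carbon would move the number beyond the scatter stays open, as does the effect of replacing the 4-(methylsulfanyl)phenyl group.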